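This account rests on a few compounds, and the source may have more. Where it says the series, first, only, none or still open, it means among the compounds named here.

Working notes on the triazole series. Compound 3 `O=C1O[C@H]([C@@H](O)Cn2cc(C3CC3)nn2)C(OCc2ccccc2)=C1OCc1ccccc1` stands at the higher of the two numbered values in a functional assay on HCT-116 cells (Homo sapiens) for antiproliferative activity, read by MTT assay, with a stated time of 72 h (a lower number here means a stronger inhibitor, a higher number a weaker inhibitor), giving 30400 nM. Compound 1 `CCCCc1cn(C[C@H](O)[C@H]2OC(=O)C(OCc3ccccc3)=C2OCc2ccccc2)nn1` gives 10400 nM in this assay, and the step of a 2.9-fold higher number from compound 1 to compound 3 (0.47 log units; beyond the scatter) separates them. Compound 2 `COc1ccccc1-c1cn(C[C@H](O)[C@H]2OC(=O)C(OCc3ccccc3)=C2OCc2ccccc2)nn1` returns only a limit of this assay, > 100000 nM; this is the case described by the limit of > 100000 nM in this assay, at which 1 of the 3 values shown sits. The step of an at least 9.6-fold higher number from compound 1 to compound 2 (0.98 log units; beyond the scatter) is therefore itself a limit, as is an at least 3.2-fold lower number from compound 2 to compound 3 (0.51 log units; beyond the scatter).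

The next step replaces the cyclopropyl on compound 3: (((4-methylphenyl)sulfonyl)amino)methyl in place of cyclopropyl on an aromatic carbon, giving compound 4 `Cc1ccc(S(=O)(=O)NCc2cn(C[C@H](O)[C@H]3OC(=O)C(OCc4ccccc4)=C3OCc3ccccc3)nn2)cc1`. Among the compounds with values here, two measured steps bear on it. Both replacements of butyl so far raised the number: the change to cyclopropyl by a 2.9-fold higher number from compound 1 to compound 3 (0.47 log units; beyond the scatter), the change to the aromatic 2-methoxyphenyl to a limit by an at least 9.6-fold higher number from compound 1 to compound 2 (0.98 log units; beyond the scatter). The entering group is larger than either and carries an aromatic ring, so a higher number than compound 3 is expected, with a real chance that this assay again reports only a limit. The expected step is a 2.1-fold higher number from compound 3 to compound 4 (0.33 log units; beyond the scatter). For compound 4 the estimate in this assay is 65000 nM, with a range from 18000 nM to 200000 nM.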

Compound 4, half-maximal inhibitory concentration: 13100 nM
Beside the measured number, compound 4's estimate is 5.0-fold (0.70 log units) above it; measured number outside the range, below it.
By their numbers in this assay, from the lowest: compounds 1 and 4 (each within the scatter of the next); then compound 3. At a limit, above all of these: compound 2.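

At this position on the five-membered aromatic ring, a much larger group carrying an aromatic ring need not raise the number: in this assay, (((4-methylphenyl)sulfonyl)amino)methyl in place of cyclopropyl gives a 2.3-fold lower number from compound 3 to compound 4 (0.37 log units; beyond the scatter), whereas both replacements of butyl seen earlier went upward. The presence of an aromatic ring in the entering group therefore does not set the outcome on its own, and the comparison with the 2-methoxyphenyl group gives an at least 7.6-fold lower number from compound 2 to compound 4 (0.88 log units; beyond the scatter), a step that is itself a limit, set by compound 2: the limit of > 100000 nM in this assay, at which 1 of the 4 values shown sits. The step of a 1.3-fold higher number from compound 1 to compound 4 (0.10 log units; within the scatter) does not separate the ((4-methylphenyl)sulfonyl)amino end from the propyl end of the chain on this saturated carbon, so two very different groups meet at the same level in this assay.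

The compounds shown do not separate what the sulfonyl, the amino hydrogen and the 4-methylphenyl ring each contribute to the step from compound 3. On these data alone, it also remains open whether a primary amine, a carboxylic acid or a longer alkyl chain at this position would reach a lower number than compound 1 and compound 4.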